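The source may report more compounds than this note shows. Statements on the series, on what has been measured and on what is new or still open speak of the compounds shown alone.

Working notes on the series. Going by the values given here, in a functional assay on DU-145 cells (Homo sapiens) for inhibition, read by trypan blue exclusion, with a stated time of 96 h (on this read-out lower numbers stand for stronger inhibition of growth and higher numbers for weaker inhibition of growth), compound 3 `COc1ccc(/C=C(/Sc2ccc(C)cc2)C(=O)c2ccc(Cl)cc2)cc1` gives 1000 nM, the lowest number so far, and the nearest number, from compound 1 `Cc1cc(C)cc(/C=C(/Sc2ccc(Br)cc2)C(=O)c2ccc(Cl)cc2)c1` at 10000 nM, lies beyond the scatter. Compound 2 `CN(C)c1ccc(/C=C(/Sc2ccc(Br)cc2)C(=O)c2ccc(Cl)cc2)cc1` reads > 100000 nM, which is a limit and not a number.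

Compound 4 `COc1ccc(/C=C(/Sc2ccc(Br)cc2)C(=O)c2ccc(Cl)cc2)cc1` has not yet been measured. It differs from compound 3 by bromo in place of methyl on an aromatic carbon, para to a large group, so that 4-methylphenyl becomes 4-bromophenyl.

Among the compounds with values here, the only measured step is an at least 10-fold higher number from compound 1 to compound 2 (1.00 log units; beyond the scatter). It is large, but it leaves the (4-bromophenyl)sulfanyl group untouched, so it bears on this change only indirectly. Within the data shown here, no measured pair isolates methyl against bromo. Compound 4 shares the (4-bromophenyl)sulfanyl group with compound 1 at 10000 nM, but the two also differ at the other aryl group, so that number gives only a slight upward lean. In this assay, the expected change is small and is not expected to clearly exceed the scatter: a 2.0-fold higher number from compound 3 to compound 4 (0.30 log units; within the scatter).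

For compound 4 the estimated value is 2000 nM, with an expected range of 500 nM to 8000 nM.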

Compound 4, concentration for 50% growth inhibition: 50000 nM
Beside the measured number, compound 4's estimate is 25-fold (1.40 log units) below it; the whole stated range lies below it.
By their numbers in this assay, from the lowest: compound 3; then compound 1; then compound 4. At a limit, above all of these: compound 2.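

Bromo in place of methyl on an aromatic carbon, para to a large group, gives a 50-fold higher number from compound 3 to compound 4 (1.70 log units; beyond the scatter) in this assay, so this position, which no earlier pair isolated, is sensitive to this single-atom change. With the (4-bromophenyl)sulfanyl group held fixed, 4-methoxyphenyl in place of 3,5-dimethylphenyl gives a 5.0-fold higher number from compound 1 to compound 4 (0.70 log units; beyond the scatter), which shows that the aryl group on the chain also moves the number when this sulfanyl group is present. The step for methoxy in place of dimethylamino reads an at least 2.0-fold lower number from compound 2 to compound 4 (0.30 log units; that floor lies within the scatter), and this is only a floor set by a limit, not a measured size: the limit of > 100000 nM in this assay, at which 1 of the 4 values shown sits.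

As far as these compounds go, the large methyl-to-bromo step rests on one pair with a 4-methoxyphenyl group on the chain, so whether it holds with other aryl groups there remains open. The compounds shown also leave open how other groups at this position, such as fluoro, a nitrile or an amine, would read against methyl and bromo, and whether the number changes gradually or sharply across such groups.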